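This account rests on a few compounds, and the source may have more. Where it says the series, first, only, none or still open, it means among the compounds named here.

Compound 3 `Cc1ccc(OCC(=O)N(C)Cc2cccs2)cc1` is the anchor of this small set: in an assay on HEK293 cells for agonist activity at transient receptor potential cation channel subfamily M member 8 (Homo sapiens), read by fluorescence and calcium flux, with a stated time of 15 min (on this read-out higher numbers stand for an effect only at larger amounts of compound and lower numbers for an effect already at smaller amounts), compound 3 gives 400 nM, the lowest of the three numbers. Compound 1 `Cc1ccc(OCC(=O)N(Cc2cccs2)C2CCCCC2)cc1` gives 40000 nM, and compound 2 `Cc1ccc(OCC(=O)N(Cc2cccs2)C(C)(C)C)cc1` gives 11000 nM. The measured steps of a 3.6-fold lower number from compound 1 to compound 2 (0.56 log units; beyond the scatter), a 100-fold lower number from compound 1 to compound 3 (2.00 log units; beyond the scatter) and a 28-fold lower number from compound 2 to compound 3 (1.44 log units; beyond the scatter) all run the same way, each move to a smaller group on the amide-type nitrogen bringing a lower number. Compound 4 `Cc1ccc(OCC(=O)N(O)Cc2cccs2)cc1` has not yet been measured. It differs from compound 3 by hydroxy in place of methyl on an amide-type nitrogen. Within the data shown here, no measured step tries a hydroxy on this nitrogen, so there is no direct precedent; what the set does show is that the large cyclohexyl and tert-butyl groups carried the high numbers, while the hydroxy, like the methyl, is a small group. For compound 4 the expected step is a 2.0-fold higher number from compound 3 to compound 4 (0.30 log units; within the scatter). Compound 4 is estimated in this assay at 800 nM, with a range from 150 nM to 5000 nM.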

Compound 4, half-maximal effective concentration: 8000 nM
Compound 4: the middle estimate sits 10-fold (1.00 log units) below what was measured; measured number outside the range, above it.
By their numbers in this assay, from the lowest: compound 3; then compounds 4 and 2 (each within the scatter of the next); then compound 1.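

The number at this amide-type nitrogen does not follow the count of heavy atoms alone: hydroxy and methyl each bring one heavy atom, yet in this assay the exchange gives a 20-fold higher number from compound 3 to compound 4 (1.30 log units; beyond the scatter) and breaks the earlier run in which the smaller group carried the lower number. Among these compounds, compound 4, the one compound here whose group on this nitrogen has a hydrogen-bond donor, cannot be told apart from the much larger tert-butyl (a 1.4-fold lower number from compound 2 to compound 4 (0.14 log units; within the scatter)), while it still stands clear of the cyclohexyl (a 5.0-fold lower number from compound 1 to compound 4 (0.70 log units; beyond the scatter)). Nothing given here explains the gap between methyl and hydroxy.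

The compounds shown leave open whether the jump belongs to the oxygen or to its hydrogen, which a methoxy on this nitrogen would help to separate. They also leave open how the amide hydrogen, an ethyl or an amino group would fall on this scale.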